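The source may report more compounds than this note shows. Statements on the series, on what has been measured and on what is new or still open speak of the compounds shown alone.

Measured compounds:
compound 1 `O=C(Nc1cccc(-n2cc(-c3ccncc3)c(-c3cc(O)cc(Cl)c3)n2)c1)Nc1ccc(Cl)c(C(F)(F)F)c1` gives 94% in a functional assay on IGROV-1 cells (Homo sapiens) for inhibition, read by sulforhodamine B assay, with a stated time of 48 h, tested at 0.01 uM; on this read-out higher numbers stand for a weaker effect at the one concentration tested and lower numbers for a stronger effect;
compound 2 `COc1cc(Cl)cc(-c2nn(-c3cccc(NC(=O)Nc4ccc(Cl)c(C(F)(F)F)c4)c3)cc2-c2ccncc2)c1` gives 112% in this assay.

For the measured compounds named here, compound 2 stands highest of the two numbers in this assay; the one step measured, a number 18 percentage points higher from compound 1 to compound 2 (beyond the scatter), is a methyl in place of hydrogen on an oxygen on an aromatic ring. Compound 3 `COc1cc(Cl)cc(-c2nn(-c3cccc(NC(=O)c4cccc(C(F)(F)F)c4)c3)cc2-c2ccncc2)c1` differs from compound 2 by 3-(trifluoromethyl)phenyl in place of (4-chloro-3-(trifluoromethyl)phenyl)amino on a carbonyl carbon. Going by the values given here, no measured step touches the carbonyl carbon or its neighbours, so nothing here bears on this change, and the two values both lie near the top of the scale at the one concentration. A step of a number 10 percentage points lower from compound 2 to compound 3 (within the scatter) is therefore expected, within the scatter. For compound 3 the estimate is 102%, with a range of 82% to 122%.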

Compound 3, a percentage reported as activity, at one concentration (the size of the read-out at that concentration, not a potency): 94%
Beside the measured number, compound 3's estimate is 8 percentage points above it, within the range that was stated.
By their numbers in this assay, from the lowest: compounds 1 and 3 (each within the scatter of the next); then compound 2.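

In this assay, for the compounds shown here, the substituent on the carbonyl carbon affects the read-out: 3-(trifluoromethyl)phenyl in place of (4-chloro-3-(trifluoromethyl)phenyl)amino gives a number 18 percentage points lower from compound 2 to compound 3 (beyond the scatter), the first measured step at this place. This single change removes both the amino nitrogen and the chlorine, so the step cannot be assigned to either one. No evidence on hand explains the step.

Open, as far as these compounds go, is which of the two departures carries the step. A (3-(trifluoromethyl)phenyl)amino group on the same carbonyl carbon would keep the nitrogen without the chlorine and separate them.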